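Swapping the Para Group on a Dithiocarbonate Aryl Ketone

The compounds below may be only part of what the source reports. "The series", "measured", "known", "first", "only" and "open" are said of these compounds alone.

Three compounds share one core and differ only in what sits on the aromatic ring. In a functional assay on HeLa cells (Homo sapiens) for antiproliferative activity, read by resazurin assay (on this read-out higher numbers stand for weaker inhibition and lower numbers for stronger inhibition), compound 1 `CCSC(=S)SCC(=O)c1cccc(OC)c1` gives 5010 nM, compound 2 `CCSC(=S)SCC(=O)c1ccc(Cl)c(Cl)c1` gives 7940 nM, and compound 3 `CCSC(=S)SCC(=O)c1ccc(S(N)(=O)=O)cc1` gives 20000 nM, the highest of the three numbers, so compound 3 is the weakest inhibitor of the set, with its gaps to both others beyond the scatter. Compound 4 `CCSC(=S)SCC(=O)c1ccc(N(CC)CC)cc1` is the untested one. It differs from compound 3 in this way: diethylamino in place of sulfamoyl on an aromatic carbon. Since compound 1 with 5010 nM and compound 2 with 7940 nM both sit lower than compound 3, the estimated step of a 3.2-fold lower number from compound 3 to compound 4 (0.50 log units; beyond the scatter) is expected to be a moderate move toward stronger inhibition. In this assay compound 4 is therefore expected to give about 6300 nM, within a range from 2000 nM to 20000 nM.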

Compound 4, half-maximal inhibitory concentration: 3160 nM
Compound 4: middle estimate off by 2.0-fold (0.30 log units), on the high side, and the stated range covers the measured number.
By their numbers in this assay, from the lowest: compounds 4, 1 and 2 (each within the scatter of the next, the first and the last beyond it); then compound 3.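

Putting diethylamino in place of sulfamoyl gives a 6.3-fold lower number from compound 3 to compound 4 (0.80 log units; beyond the scatter) in this set's first comparison that changes only one place. It shows that the group on this aromatic carbon can, on its own, move the number beyond the scatter. The entering group has no hydrogen-bond donor and the leaving group has one, but no measurement here explains the step.

As far as these compounds go, whether a plain amine or a carboxylic acid on this carbon would lower or raise the number remains open. So does the effect of longer chains on the nitrogen.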